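A Fluoro-Methoxyphenyl Swap on a Weak Cell Growth Inhibitor

This account rests on a few compounds, and the source may have more. Where it says the series, first, only, none or still open, it means among the compounds named here.

Compound 1, `Cn1ccc2cc(-c3cc4nccc(-c5ccc(F)cc5)n4n3)ccc21`, gives 2160 nM.
Compound 3, `COc1cc(-c2ccnc3cc(-c4cn(C(=O)OC(C)(C)C)c5ccccc45)nn23)cc(OC)c1OC`, gives 5720 nM.
Compound 2, `COc1cc(-c2ccnc3cc(-c4cccc(C#N)c4)nn23)cc(OC)c1OC`, reaches only the limit of > 10000 nM.

These numbers come from a functional assay on HCT-116 cells (Homo sapiens) for inhibition, read by CCK-8 assay, with a stated time of 48 h; a higher number here means a weaker inhibitor, a lower number a stronger inhibitor. Compound 2 stands apart: its result is not a number but a limit, (the limit of > 10000 nM in this assay, at which 1 of the 3 values shown sits). For the measured compounds named here, the other two compounds, with different groups at different places on the shared core, give ordinary numbers, compound 1 at 2160 nM and compound 3 at 5720 nM, but neither differs from compound 2 in just one place, so no measured step links them.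

Compound 4, `COc1ccc(-c2cc3nccc(-c4cc(OC)c(OC)c(OC)c4)n3n2)cc1F`, is the untested compound. It keeps the rest of compound 2 and changes one group: 3-fluoro-4-methoxyphenyl in place of 3-cyanophenyl on an aromatic carbon. The ring that enters carries a fluorine and a methoxy group where the nitrile ring used to be.

Going by the values given here, with no measured step of this kind available, any expectation rests on compound 2 sitting at a limit and on the modest results of compound 1 and compound 3. A move toward stronger inhibition would not be surprising, and the step is estimated as an at least 1.4-fold lower number from compound 2 to compound 4 (0.15 log units; that floor lies within the scatter), though the limit on compound 2 makes its size uncertain. Compound 4 is expected at about 7000 nM, within 2500 nM to 20000 nM.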

Compound 4, half-maximal inhibitory concentration: 2840 nM
Beside the measured number, compound 4's estimate is 2.5-fold (0.39 log units) above it; measured number inside the range.
By their numbers in this assay, from the lowest: compounds 1, 4 and 3 (each within the scatter of the next, the first and the last beyond it). At a limit, above all of these: compound 2.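

Putting 3-fluoro-4-methoxyphenyl in place of 3-cyanophenyl on this aromatic carbon of the five-membered ring gives, in this assay, an at least 3.5-fold lower number from compound 2 to compound 4 (0.54 log units; beyond the scatter). This is the only pair shown that differs in just one place, so it is the only direct sign that the group held at this position can change the result in these cells, with everything else on the shared core kept the same. On these data alone, the step can be stated only as a minimum, and its full size stays unknown, because compound 2 has a limit rather than a number: the limit of > 10000 nM in this assay, at which 1 of the 4 values shown sits.

As far as these compounds go, it remains open whether the fluorine, the methoxy group or the two together account for the step, which a phenyl ring carrying only one of them at the same place on the ring would help to separate. From the compounds shown here alone, it is equally open how this position would respond to a group of a different kind, such as an amine or a carboxylic acid on that phenyl ring.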